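Triazole-linked pyridopyrimidinones: antiproliferative notes, compound 3 to 4

A few compounds are considered here, and "the series" means these few. Any claim that something is new, unique, unknown or untested is made for them only; others in the source may bear on it.

Measured so far in a functional assay on A549 cells (Homo sapiens) for antiproliferative activity, read by sulforhodamine B assay, with a stated time of 48 h; a lower number here means a stronger inhibitor of growth, a higher number a weaker inhibitor of growth:
compound 1 `O=c1c2ccc(C(F)(F)F)nc2ncn1Cc1cc(-c2ccc(Br)cc2)no1`: 3810 nM
compound 2 `CCc1nc2nc(C(F)(F)F)ccc2c(=O)n1Cc1cn(CCC(F)(F)C(F)(F)C(F)(F)C(F)(F)C(F)(F)C(F)(F)F)nn1`: 30 nM
compound 3 `O=C(Cn1cc(COc2nc(-c3ccccc3)nc3nc(C(F)(F)F)ccc23)nn1)Nc1ccccc1`: 140 nM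

Compound 3 holds the second highest of the three numbers in this assay. Compound 2 sits nearest, with a number well below that of compound 3 and beyond the scatter, while compound 1 lies furthest, far above and also beyond the scatter. Among the compounds with values here, no pair of measured compounds differs in one place, so no step has been quantified.

Compound 4 `COc1cc(-n2cc(COc3nc(-c4ccccc4)nc4nc(C(F)(F)F)ccc34)nn2)cc(OC)c1OC` differs from compound 3 by 3,4,5-trimethoxyphenyl in place of (phenylcarbamoyl)methyl on an aromatic nitrogen. Within the data shown here, with no comparable step on record, the direction can only be guessed from the absence of a donor in the entering group and the unchanged rest of the molecule. A modest step to a lower number is expected, a 1.8-fold lower number from compound 3 to compound 4 (0.24 log units; within the scatter), though the range must stay wide. Compound 4 is estimated at 80 nM, between 15 nM and 400 nM.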

Compound 4, concentration for 50% growth inhibition: 4050 nM
Compound 4: middle estimate off by 51-fold (1.70 log units), on the low side; measured number above the stated range.
By their numbers in this assay, from the lowest: compound 2; then compound 3; then compounds 1 and 4 (each within the scatter of the next).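

Within the data shown here, on the aromatic nitrogen of the five-membered ring, this assay proves highly sensitive to the group carried: 3,4,5-trimethoxyphenyl in place of (phenylcarbamoyl)methyl gives the first quantified step (a 29-fold higher number from compound 3 to compound 4 (1.46 log units; beyond the scatter)). The rest of the molecule is unchanged, so the loss of growth inhibition is tied to this one position. Nothing measured here bears on what lies behind the step.

Which part of the exchange matters stays open, since the amide hydrogen, the carbonyl and the methoxy groups all change together. A plain phenyl on the same nitrogen, or a carboxylic acid in place of the phenylcarbamoyl part, would help separate them.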